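Ester chain variation in the cinnamate series: gastric stability

This account rests on a few compounds, and the source may have more. Where it says the series, first, only, none or still open, it means among the compounds named here.

Compound 2 `CCOc1cc(NC(=O)C2(NC(=O)c3ccc4c(C5CCCC5)c(-c5ncc(Cl)cn5)n(C)c4c3)CCC2)ccc1/C=C/C(=O)OCC(C)C` carries the shared core of compound 1 `CCCOC(=O)/C=C/c1ccc(NC(=O)C2(NC(=O)c3ccc4c(C5CCCC5)c(-c5ncc(Cl)cn5)n(C)c4c3)CCC2)cc1OCC` with an isobutyl ester at the chain end. In an ADME assay on stomach for pharmacokinetics, in simulated gastric fluid (a higher number here means that the compound lasts longer, a lower number that the compound disappears faster), compound 2 gives 1.43 h. On the numbers shown compound 2 stands lowest of the two measured, with compound 1 nearest; in this assay compound 1 gives 2.23 h, and the step of a 1.6-fold lower number from compound 1 to compound 2 (0.19 log units; within the scatter) stays within the scatter. Compound 3 `CCOc1cc(NC(=O)C2(NC(=O)c3ccc4c(C5CCCC5)c(-c5ncc(Cl)cn5)n(C)c4c3)CCC2)ccc1/C=C/C(=O)OCC(N)=O` has not been measured in this assay. It differs from compound 2 by carbamoyl in place of isopropyl on a saturated chain carbon bound to an oxygen next to a carbonyl group. Going by the values given here, the only measured step, a 1.6-fold lower number from compound 1 to compound 2 (0.19 log units; within the scatter), touches the same ester chain but is a smaller edit than the exchange from compound 2 to compound 3, and it produced no step beyond the scatter. Among the compounds with values here, no measured pair shows a carbamoyl group entering at this place, so the direction of any step is not anchored by the data. On this basis the half-life of compound 3 in this assay is expected to stay close to that of compound 2, with an estimated step of a 1.0-fold higher number from compound 2 to compound 3 (0.02 log units; within the scatter) that is not expected to exceed the scatter. Compound 3 is therefore estimated at 1.5 h, with a range from 0.7 h to 3.2 h.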

Compound 3, half-life: 0.6 h
For compound 3 the middle estimate is 2.5-fold (0.40 log units) above the measured one, outside the stated range (below it).
By their numbers in this assay, from the lowest: compound 3; then compounds 2 and 1 (each within the scatter of the next).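

At the saturated chain carbon bound to an oxygen next to a carbonyl group, the ester chain is not indifferent to what it carries in this assay: carbamoyl in place of isopropyl gives a 2.4-fold lower number from compound 2 to compound 3 (0.38 log units; beyond the scatter) and carbamoyl in place of ethyl gives a 3.7-fold lower number from compound 1 to compound 3 (0.57 log units; beyond the scatter), while the exchange between the two alkyl esters stayed at a 1.6-fold lower number from compound 1 to compound 2 (0.19 log units; within the scatter) and so showed no difference. Among the compounds shown, the carbamoylmethyl ester of compound 3 is therefore the only one set apart, with compounds 1 and 2 within the scatter of each other and both steps to compound 3 running the same way, though each is only modest in size. Nothing at hand bears on why the half-life differs at this position.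

Still open, as far as these compounds go, is whether this step belongs to the carbamoyl group as such or would also appear with a carboxylic acid, an amine or a dimethylcarbamoyl group on the same carbon. A longer chain between this carbon and the carbamoyl group would show whether the step depends on how close that group stands to the ester oxygen.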